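Cytotoxicity of a positional fluorine isomer in the series

A few compounds are considered here, and "the series" means these few. Any claim that something is new, unique, unknown or untested is made for them only; others in the source may bear on it.

Compound 2 `CCOC(=O)CCCCCOc1cccc(CN(C(=O)c2ccc(-c3cc(F)cc(OC)c3)cc2)C(C)C)c1` has been tested in an ADME assay on HEK293 cells (Homo sapiens) for cytotoxicity, read by CellTiter-Glo and resazurin assay, with a stated time of 72 h; a higher number here means that more compound is needed for the effect, a lower number that less compound is needed. In this assay compound 2 gives only the limit > 26000 nM, a boundary of the measurement rather than a number. Compound 1 `CCOC(=O)CCCCCOc1cccc(CN(C(=O)c2ccc(-c3cccc(OCC(C)C)c3)cc2)C(C)C)c1` carries 3-(isobutoxy)phenyl where compound 2 carries 3-fluoro-5-methoxyphenyl, and in this assay compound 1 likewise gives only the limit > 26000 nM. The step that the two limits leave unreadable from compound 1 to compound 2 thus cannot be read in size or direction; what stands is the limit of > 26000 nM in this assay, at which 2 of the 2 values shown sit. Compound 3 `CCOC(=O)CCCCCOc1cccc(CN(C(=O)c2ccc(-c3cc(OC)ccc3F)cc2)C(C)C)c1` is not yet measured; it differs from compound 2 by 2-fluoro-5-methoxyphenyl in place of 3-fluoro-5-methoxyphenyl on an aromatic carbon. No readable measured step bears on this change, and no numeric value exists in the series to set a size of step; nothing points to a departure beyond the scatter. Compound 3 is expected to sit at 40000 nM, between 18000 nM and 120000 nM, most likely again reported only as a limit, which means an expected step that the limit leaves unreadable from compound 2 to compound 3.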

Compound 3, half-maximal effective concentration: > 26000 nM
Compound 3: no number, only a limit (the forecaster's own chance of this, stated with the estimate: 85%); the middle value lies beyond the limit too.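

In this assay, within the data shown here, compound 3, like compound 1 and compound 2, gives only a limit, so no step among the three can be read. From the compounds shown here alone, it remains open at what concentration any of the three would show an effect in this assay and whether 2-fluoro-5-methoxyphenyl and 3-fluoro-5-methoxyphenyl differ at all.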